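Swapping a Ring Substituent on a Shared Core

The source may report more compounds than this note shows. Statements on the series, on what has been measured and on what is new or still open speak of the compounds shown alone.

Of the compounds shown here, two built on one shared core have been tested in a functional assay on LNCaP cells (Homo sapiens) for antiproliferative activity; on this read-out higher numbers stand for weaker inhibition and lower numbers for stronger inhibition. Compound 1 `Cn1ncc(Cl)c1-c1cc(C(=O)N[C@@H]2CN[C@H](CC(O)CO)C[C@H]2c2ccc(F)c(F)c2)oc1Cl` gives 100 nM in this assay. Compound 2 `Cn1ncc(Cl)c1-c1cc(C(=O)N[C@@H]2CN[C@H](CCN3CCC(O)CC3)C[C@H]2c2ccc(Cl)c(Cl)c2)oc1Cl` gives 1140 nM in this assay, the higher of the two numbers and well apart from compound 1; the two differ in more than one place, so the two values can only be set side by side and not traced to a single change.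

Compound 3 `Cn1ncc(Cl)c1-c1cc(C(=O)N[C@@H]2CN[C@H](CCN3CCCC3)C[C@H]2c2ccc(Cl)c(Cl)c2)oc1Cl` is not yet measured. It differs from compound 2 in one place: pyrrolidin-1-yl in place of 4-hydroxypiperidin-1-yl on a saturated chain carbon, two bonds along the chain from a saturated ring carbon. The group that leaves carries 1 hydrogen-bond donor and 2 hydrogen-bond acceptors; the pyrrolidin-1-yl that enters carries 0 hydrogen-bond donors and 1 hydrogen-bond acceptor.

For the measured compounds named here, no measured pair shows what such a change does on this core, so there is no basis for expecting a large move in either direction. The estimated step of a 1.3-fold lower number from compound 2 to compound 3 (0.13 log units; within the scatter) is small, with a slight lean toward a lower number, and is expected to stay within the usual scatter. Compound 3 is expected to give about 850 nM in this assay, most likely between 250 nM and 2800 nM.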

Compound 3, half-maximal inhibitory concentration: 1920 nM
Estimate against measurement, compound 3: 2.3-fold (0.35 log units) below; the measured number falls inside the stated range.
By their numbers in this assay, from the lowest: compound 1; then compounds 2 and 3 (each within the scatter of the next).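

In this assay, the change from 2-(4-hydroxypiperidin-1-yl)ethyl to 2-(pyrrolidin-1-yl)ethyl is a 1.7-fold higher number from compound 2 to compound 3 (0.23 log units; within the scatter), so the two compounds cannot be told apart on this read-out. For the compounds shown here, this is the first comparison on the shared core that isolates a single place, and it shows that this swap at the end of the chain, from a six-membered ring with a hydrogen-bond donor to a five-membered ring with no hydrogen-bond donors, leaves no effect that can be separated from ordinary assay variation. No measurement shown here offers an explanation for this result.

Because the swap alters the ring size and removes the hydroxyl in one step, this pair cannot show what either alteration does alone, or whether the two happen to offset each other; a plain piperidin-1-yl group on the same chain would separate them. As far as these compounds go, it also remains open whether groups of a different kind at this place, such as a morpholin-4-yl ring, a primary amine or a carboxylic acid, would give a step beyond the scatter.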